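The source may report more compounds than this note shows. Statements on the series, on what has been measured and on what is new or still open speak of the compounds shown alone.

Measured in an ADME assay on L1210/0 cells (Mus musculus) for cytotoxicity, with a stated time of 48 h; a lower number here means a stronger inhibitor, a higher number a weaker inhibitor:
Compound 1 `OC[C@@H]1C[C@H](Cn2cnc3c(NC4CC4)ncnc32)c2c(-c3ccccc3)nnc(-c3ccccc3)c21` gives > 200000 nM as a limit of the assay
Compound 2 `N#CSc1cn([C@H]2C[C@H](O)[C@@H](CO)O2)c(=O)[nH]c1=O` gives 78900 nM

Among the compounds with values here, compound 2 is the only measured compound with an actual number (78900 nM) and so is the sole numerical reference. Compound 3 `O=C(CI)NCc1cn([C@H]2C[C@H](O)[C@@H](CO)O2)c(=O)[nH]c1=O` carries (((iodomethyl)carbonyl)amino)methyl in place of cyanosulfanyl on an aromatic carbon. Within the data shown here, no measured step covers this change, so the expectation is loose: a modest move toward stronger inhibition in this assay is expected. The expected change is a 2.6-fold lower number from compound 2 to compound 3 (0.42 log units; beyond the scatter) in that direction. For compound 3 the estimated value is 30000 nM with an expected range of 5000 nM to 150000 nM.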

Compound 3, half-maximal inhibitory concentration: 107000 nM
Compound 3: the middle estimate sits 3.6-fold (0.55 log units) below what was measured; the measured number falls inside the stated range.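

At this aromatic carbon, two atoms from the ring nitrogen, (((iodomethyl)carbonyl)amino)methyl in place of cyanosulfanyl gives a 1.4-fold higher number from compound 2 to compound 3 (0.13 log units; within the scatter) in this assay. This position therefore takes a group of 6 heavy atoms, with an amide hydrogen and an iodine, in place of one of 3 heavy atoms, with no change beyond the scatter. No measurement shown bears on why the two values stay so close.

From the compounds shown here alone, whether the iodine matters remains open. So does how a simple aminomethyl, a carboxylic acid or a longer alkyl chain at this carbon would read in this assay.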